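The source may hold more compounds than are shown below. What is called first, only, known or untested is meant among the compounds shown, and "the series" means these compounds.

Compound 3, `CN(C)Cc1ccc2nc(NC(=O)N/N=C/c3cn(Cc4ccccc4Cl)c4ccccc34)sc2c1`, gives 1180 nM in a functional assay on MDA-MB-231 cells (Homo sapiens) for cytotoxicity, read by MTT assay, with a stated time of 72 h (on this read-out lower numbers stand for stronger inhibition and higher numbers for weaker inhibition), and stands second highest of the three numbers measured there. Among the compounds with values here, its nearest neighbour is compound 1, `CCN(CC)Cc1ccc2nc(NC(=O)N/N=C/c3cn(Cc4ccccc4Cl)c4ccccc34)sc2c1`, which in this assay gives 900 nM; the step of a 1.3-fold higher number from compound 1 to compound 3 (0.12 log units; within the scatter) is the only one-place change among the measured compounds and lies within the scatter. Furthest away is compound 2, `CC1CCN(Cc2ccc3nc(NC(=O)N/N=C/c4cn(Cc5ccc(Cl)cc5Cl)c5ccccc45)sc3c2)CC1`, which in this assay gives 3140 nM, a gap beyond the scatter; compound 2 differs from compound 3 in two places, so its two values alone show a higher number where a second chloro group and a different amine are both present.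

Compound 4, `CN(C)Cc1ccc2nc(NC(=O)N/N=C/c3cn(Cc4ccc(Cl)cc4Cl)c4ccccc34)sc2c1`, follows from compound 3 by chloro in place of hydrogen on an aromatic carbon. No measured step isolates this change, so the expectation rests only on the higher number shown by compound 2. A modest rise is expected, with the step of a 1.7-fold higher number from compound 3 to compound 4 (0.23 log units; within the scatter) estimated to stay near the edge of the scatter. Compound 4 is therefore expected to give about 2000 nM in this assay, within a range from 900 nM to 4500 nM.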

Compound 4, half-maximal inhibitory concentration: 1410 nM
The estimate for compound 4 lay 1.4-fold (0.15 log units) above the measured number; measured number inside the range.
By their numbers in this assay, from the lowest: compounds 1, 3 and 4 (each within the scatter of the next); then compound 2.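

The change from 2-chlorobenzyl to 2,4-dichlorobenzyl can now be read on its own: it gives a 1.2-fold higher number from compound 3 to compound 4 (0.08 log units; within the scatter) in this assay, so a chloro group para to a large group leaves no readable mark on this number. With the 2,4-dichlorobenzyl group held constant, dimethylamino in place of 4-methylpiperidin-1-yl gives a 2.2-fold lower number from compound 2 to compound 4 (0.35 log units; beyond the scatter), so the gap that compound 2 showed goes with the amine and not with the added chloro group. Nothing measured here says why either step has the size it has.

On these data alone, whether a methoxy group or a fluoro group at the same place would behave like chloro remains open. So does whether a morpholine or a piperazine in place of the amine would follow dimethylamino or 4-methylpiperidin-1-yl.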